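The source may report more compounds than this note shows. Statements on the series, on what has been measured and on what is new or still open speak of the compounds shown alone.

Compound 3 `c1ccc2c(c1)CC(CCCN1CCN(c3cccc4c3OCCO4)CC1)C2` stands highest of the three measured compounds in an assay on isolated protein for binding affinity to 5-hydroxytryptamine receptor 1B (Rattus norvegicus) (on this read-out lower numbers stand for stronger inhibition and higher numbers for weaker inhibition), where compound 3 gives 1860 nM. Its nearest neighbour is compound 1 `c1ccc2c(c1)CC2CCCCN1CCN(c2cccc3c2OCCO3)CC1`, which in this assay gives 631 nM; furthest away is compound 2 `c1ccc2c(c1)CCC2CCCN1CCN(c2cccc3c2OCCO3)CC1`, which in this assay gives 204 nM. The step from compound 3 to compound 4 `Clc1cccc2c1CC2CCCN1CCN(c2cccc3c2OCCO3)CC1` is a group of 9 heavy atoms (8 carbon, 1 chlorine; one four-membered non-aromatic ring of carbon only, one six-membered aromatic ring of carbon only) in place of a group of 9 heavy atoms (9 carbon; one five-membered non-aromatic ring of carbon only, one six-membered aromatic ring of carbon only), on a saturated chain carbon, three bonds along the chain from an amine nitrogen in a ring. Among the compounds with values here, two measured steps bear on it: a 2.9-fold higher number from compound 1 to compound 3 (0.47 log units; beyond the scatter) and a 9.1-fold higher number from compound 2 to compound 3 (0.96 log units; beyond the scatter), both running toward compound 3 and both higher; the third, a 3.1-fold lower number from compound 1 to compound 2 (0.49 log units; beyond the scatter), separates the two lower compounds. Within the data shown here, compound 4 carries a four-membered ring, as compound 1 does, with a chlorine added, so reversing the rise seen from compound 1 to compound 3 seems the likeliest outcome, though no measured pair shows what the chlorine alone does. Compound 4 is therefore expected to give a lower number than compound 3 in this assay, estimated as a 4.1-fold lower number from compound 3 to compound 4 (0.62 log units; beyond the scatter). The estimate for compound 4 in this assay is 450 nM, with a range from 120 nM to 1700 nM.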

Compound 4, inhibition constant: 1100 nM
Estimate against measurement, compound 4: 2.4-fold (0.39 log units) below; the range from low to high includes it.
By their numbers in this assay, from the lowest: compound 2; then compounds 1, 4 and 3 (each within the scatter of the next, the first and the last beyond it).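

In this assay, the chlorine-bearing four-membered ring group on a saturated chain carbon, three bonds along the chain from an amine nitrogen in a ring, cannot be told apart from the 2,3-dihydro-1H-inden-2-yl group, with a 1.7-fold lower number from compound 3 to compound 4 (0.23 log units; within the scatter), or from the group of compound 1, with a 1.7-fold higher number from compound 1 to compound 4 (0.24 log units; within the scatter). The 2,3-dihydro-1H-inden-1-yl group of compound 2 remains clearly ahead of the new group, with a 5.4-fold higher number from compound 2 to compound 4 (0.73 log units; beyond the scatter), and compound 2 keeps the lowest number of the four in this assay. Nothing available explains these results.

The compounds shown do not separate the contribution of the chlorine from that of the four-membered ring. They also leave open whether a fluorine or a methoxy group in the chlorine's place would give a different number.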